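The source may hold more compounds than are shown below. What is called first, only, known or untested is meant among the compounds shown, and "the series" means these compounds.

Measured compounds in a functional assay on SK-MEL-2 cells (Homo sapiens) for inhibition, read by sulforhodamine B assay, with a stated time of 48 h; a lower number here means a stronger inhibitor of growth, a higher number a weaker inhibitor of growth:
- Compound 1 `COc1cc(-c2cc(/C=C/C(=O)c3ccc(N)cc3)[nH]n2)cc(OC)c1OC`: 2850 nM
- Compound 2 `COc1ccc(-c2cc(/C=C/C(=O)c3ccc(OC)c(OC)c3)[nH]n2)cc1`: "not determined" (no result reported)
- Compound 3 `COc1ccc(-c2cc(/C=C/C(=O)c3ccc(N)cc3)[nH]n2)cc1`: "not determined" (no result reported)

Within the data shown here, compound 1 is the only member of the series with a number in this assay ; compounds 2 and 3 carry no value, so no comparison within the measured set can be drawn and no step between measured compounds is available. Compound 1 therefore stands alone as the single reference point, and its value sets the level from which any expectation for a new analogue has to start.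

Compound 4 `COc1cc(-c2cc(/C=C/C(=O)c3ccc(F)c(F)c3)[nH]n2)cc(OC)c1OC` is the next entry. Relative to compound 1 the change is 3,4-difluorophenyl in place of 4-aminophenyl on a carbonyl carbon. The shared core and the chain carrying the carbonyl are untouched ; only the aromatic ring on the carbonyl carbon is exchanged, 3,4-difluorophenyl in place of 4-aminophenyl.

With no measured step of this kind in the series, the size and direction of the change cannot be anchored. The expectation is a step of a 1.2-fold higher number from compound 1 to compound 4 (0.09 log units; within the scatter) that is small, with no clear direction beyond the usual scatter, given only the value of compound 1 2850 nM as a starting point. Compound 4 is estimated at 3500 nM in this assay, with a range from 800 nM to 15000 nM.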

Compound 4, concentration for 50% growth inhibition: 2300 nM
Compound 4: the middle estimate sits 1.5-fold (0.18 log units) above what was measured; the measured number falls inside the stated range.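

On a carbonyl carbon, 3,4-difluorophenyl in place of 4-aminophenyl gives a 1.2-fold lower number from compound 1 to compound 4 (0.09 log units; within the scatter) in this assay, the first step readable in the series, and it shows that this aromatic ring can be exchanged with no change beyond the scatter. The exchange also shows that the read-out does not separate these two groups, although 4-aminophenyl carries 1 hydrogen-bond donor and 1 hydrogen-bond acceptor, while 3,4-difluorophenyl carries 0 hydrogen-bond donors and 0 hydrogen-bond acceptors. Nothing on hand explains why the two groups are not separated.

From the compounds shown here alone, this is a single pair at a single place, so it sets no trend for other groups on the carbonyl carbon, and the shared core and the chain carrying the carbonyl remain untested by any readable step. Still open, going by these compounds, is whether a phenyl ring bearing a carboxylic acid, or a cyclohexyl ring with no aromatic character, would stay within the scatter of compound 1 or move clearly away from it.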